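A Fluorine for Chlorine Swap on the Benzyl Arm

The source may report more compounds than this note shows. Statements on the series, on what has been measured and on what is new or still open speak of the compounds shown alone.

In a functional assay on the whole organism (artery, strain albino) with Rattus norvegicus as the target, with a stated time of 60 min, at a dose of 10 mg/kg by the oral route (on this read-out higher numbers stand for more inhibition at the one dose given (going by the name of the read-out) and lower numbers for less inhibition), compound 1 `CC1=C(C(=O)Nc2ccc([N+](=O)[O-])cc2)C(c2cccc([N+](=O)[O-])c2)N=C(SCc2ccccc2Cl)N1` gives 6.7%, and compound 2 `CC1=C(C(=O)Nc2ccc([N+](=O)[O-])cc2)C(c2cccc([N+](=O)[O-])c2)N=C(SCc2cccc(Cl)c2)N1` gives 8.2%. Both numbers are small, and the two sit side by side, separated only by a number 1.5 percentage points higher from compound 1 to compound 2 (within the scatter). Compound 3 `CC1=C(C(=O)Nc2ccc([N+](=O)[O-])cc2)C(c2cccc([N+](=O)[O-])c2)N=C(SCc2ccc(F)cc2)N1` differs from compound 2 by 4-fluorophenyl in place of 3-chlorophenyl on a saturated chain carbon bound to a sulfur. For the measured compounds named here, the one measured step, a number 1.5 percentage points higher from compound 1 to compound 2 (within the scatter), swapped 2-chlorophenyl for 3-chlorophenyl on the same saturated chain carbon bound to a sulfur without leaving the scatter, so the expected step here is a number 0.7 percentage points lower from compound 2 to compound 3 (within the scatter), nothing beyond the scatter. Compound 3 is therefore estimated at 7.5%, within 0% to 18%.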

Compound 3, a percentage reported as inhibition, in the whole organism at one dose (the size of the read-out at that dose, not a potency): 7.2%
Compound 3: middle estimate off by 0.3 percentage points, on the high side; the range from low to high includes it.
By their numbers in this assay, from the lowest: compounds 1, 3 and 2 (each within the scatter of the next).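

Swapping the halogen as well as its place on the ring still does not shift the number: there is a number 1 percentage points lower from compound 2 to compound 3 (within the scatter) and a number 0.5 percentage points higher from compound 1 to compound 3 (within the scatter), both for 4-fluorophenyl on a saturated chain carbon bound to a sulfur. The 2-chlorophenyl, 3-chlorophenyl and 4-fluorophenyl groups therefore cannot be ranked, and all three compounds stay low. No measurement here offers an explanation for this flat result. From the compounds shown here alone, what stays open is whether a different group on this arm, such as an amine or a carboxylic acid in place of the halogen, would move the number beyond the scatter.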